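The source may report more compounds than this note shows. Statements on the series, on what has been measured and on what is new or still open speak of the compounds shown alone.

Series notes. Compound 1 `Cc1ccc(C)c(-n2nncc2CN2C(=O)C3(C(C#N)=C(N)Oc4c3c3nc5ccccc5nc3c3ccccc43)c3ccccc32)c1` and compound 2 `Cc1cc(C)cc(-n2nncc2CN2C(=O)C3(C(C#N)=C(N)Oc4c3c3nc5ccccc5nc3c3ccccc43)c3ccccc32)c1` share one core and differ only in 3,5-dimethylphenyl in place of 2,5-dimethylphenyl on an aromatic nitrogen. In an ADME assay on HUVEC cells (Homo sapiens) for antiproliferative activity, read by MTT assay, with a stated time of 48 h (on this read-out higher numbers stand for weaker inhibition and lower numbers for stronger inhibition), compound 1 gives > 50000 nM, which is a limit of the assay and not a number. In this assay compound 2 gives > 50000 nM, again a limit. The step that the two limits leave unreadable from compound 1 to compound 2 therefore has no readable size; both values sit at the limit of > 50000 nM in this assay, at which 3 of the 3 values shown sit.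

Compound 3 `Cc1ccc(C)c(-n2nncc2CN2C(=O)C3(C(C#N)=C(N)Oc4c(N)cc5nc6ccccc6nc5c43)c3ccccc32)c1` carries a different core, and the difference between the cores of compound 1 and compound 3 is not broken down here. In this assay compound 3 gives > 50000 nM, once more a limit. Among the measured compounds shown here, every value shown so far is a limit, as the limit of > 50000 nM in this assay, at which 3 of the 3 values shown sit, records, so no pair among compounds 1, 2 and 3 can be ordered.

Compound 4 `Cc1cc(C)cc(-n2nncc2CN2C(=O)C3(C(C#N)=C(N)Oc4c(N)cc5nc6ccccc6nc5c43)c3ccccc32)c1` has not yet been measured. It differs from compound 3 in 3,5-dimethylphenyl in place of 2,5-dimethylphenyl on an aromatic nitrogen, the same change as made between compound 1 and compound 2, with the place of the change described identically in both pairs. The step that the limit leaves unreadable from compound 3 to compound 4 is expected to be small, resting on a step that the two limits leave unreadable from compound 1 to compound 2, which the two limits left unreadable, and on the limit shown for compound 3 in this assay. For compound 4 the estimate in this assay is 80000 nM. The expected range for compound 4 runs from 30000 nM to 300000 nM, with a limit rather than a number the most likely outcome.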

Compound 4, half-maximal inhibitory concentration: > 50000 nM
Compound 4 gave a limit, no number; the forecaster's own chance of this, stated with the estimate: 85%; the middle value lies beyond the limit too.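

In this assay compound 4 gives > 50000 nM, which is a limit of the assay and not a number. No step can be read from compound 3 to compound 4, so 3,5-dimethylphenyl in place of 2,5-dimethylphenyl has no readable size in this pair or between compound 1 and compound 2. Whether either change or core alters activity remains open, because every value sits at one limit: the limit of > 50000 nM in this assay, at which 4 of the 4 values shown sit.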